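Methoxy Step Carried From One Core to Another

A few compounds are considered here, and "the series" means these few. Any claim that something is new, unique, unknown or untested is made for them only; others in the source may bear on it.

Measured compounds in an ADME assay on MT4 cells (Homo sapiens) for cytotoxicity, read by MTT assay, with a stated time of 4 days; a higher number here means that more compound is tolerated, a lower number that less compound is tolerated:
compound 1 `CC(=O)Nc1ccc2oc(-c3ccccc3)c(O)c(=O)c2c1` gives 64700 nM;
compound 2 `COc1ccccc1-c1oc2ccc(NC(C)=O)cc2c(=O)c1O` gives 385000 nM;
compound 3 `COc1c(-c2ccccc2)oc2ccc(N)cc2c1=O` gives 126000 nM.

For the measured compounds named here, the one counted step among the measured compounds is a 6.0-fold higher number from compound 1 to compound 2 (0.77 log units; beyond the scatter); the change is methoxy in place of hydrogen on an aromatic carbon. Compound 3 stands second highest of the three numbers in this assay: its gap to compound 1 is within the scatter, its gap to compound 2 beyond it. The difference between the core of compound 1 and the core of compound 3 is not broken down here.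

Compound 4 `COc1ccccc1-c1oc2ccc(N)cc2c(=O)c1OC` carries the same change made on the core of compound 3: methoxy in place of hydrogen on an aromatic carbon. The place is described in the same words for both pairs, so the change is taken as the same one, on a different core. Going by the values given here, from compound 3 to compound 4 a step of a 3.0-fold higher number from compound 3 to compound 4 (0.48 log units; beyond the scatter) is expected, set smaller than the earlier one because the only precedent is a 6.0-fold higher number from compound 1 to compound 2 (0.77 log units; beyond the scatter) and rests on a single pair on another core. For compound 4 the estimated value is 380000 nM, with an expected range from 150000 nM to 950000 nM.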

Compound 4, half-maximal cytotoxic concentration: 229000 nM
Compound 4: middle estimate off by 1.7-fold (0.22 log units), on the high side; the range from low to high includes it.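

On the core of compound 3, methoxy in place of hydrogen on an aromatic carbon gives a 1.8-fold higher number from compound 3 to compound 4 (0.26 log units; within the scatter) in this assay, a step that cannot be told apart from repeat scatter. Set beside the step on the core of compound 1, it shows that the size of the step does not carry over unchanged between these two cores: the same change on two cores in this assay, a 6.0-fold higher number (0.77 log units; beyond the scatter) from compound 1 to compound 2 and a 1.8-fold higher number (0.26 log units; within the scatter) from compound 3 to compound 4, 3.3-fold (0.52 log units) apart, beyond the scatter of two such steps
With a single pair on each core, this does not show which of the differences between the core of compound 1 and the core of compound 3 goes with the gap, and it gives no general rule for the series.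

Open, going by these compounds, is whether a pair holding the hydroxyl of compound 1 together with the amine of compound 3, or the reverse, would show the larger step or the smaller one. Also open, on these data alone, is whether ethoxy, fluoro or chloro in place of hydrogen at the same aromatic carbon would follow methoxy on either core.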